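From 6-chloropyridin-2-yl to 3-chloropyridin-2-yl on the amide

A few compounds are considered here, and "the series" means these few. Any claim that something is new, unique, unknown or untested is made for them only; others in the source may bear on it.

In a functional assay on LoVo cells (Homo sapiens) for inhibition, read by MTT assay, with a stated time of 72 h (a higher number here means a weaker inhibitor, a lower number a stronger inhibitor), compound 1 `Cc1noc(C)c1-c1cnc(N)c(Oc2ccc(C(=O)NC3CC3)cc2)n1` gives > 100000 nM, which is a limit and not a number. Compound 2 `Cc1noc(C)c1-c1cnc(N)c(Oc2ccc(C(=O)Nc3ccccc3Cl)cc2)n1` gives > 100000 nM, also a limit. For the measured compounds named here, compound 3 `Cc1noc(C)c1-c1cnc(N)c(Oc2ccc(C(=O)Nc3cccc(Cl)n3)cc2)n1` gives 39300 nM, the only true number so far. Compound 4 `Cc1noc(C)c1-c1cnc(N)c(Oc2ccc(C(=O)Nc3ncccc3Cl)cc2)n1` has the same atoms joined differently: 3-chloropyridin-2-yl in place of 6-chloropyridin-2-yl on an amide-type nitrogen. The nearest guides are an at least 2.5-fold lower number from compound 2 to compound 3 (0.40 log units; beyond the scatter) and an at least 2.5-fold lower number from compound 1 to compound 3 (0.40 log units; beyond the scatter), both beyond the scatter. Going by the values given here, they show that the amide group can matter, but no measured step exchanges one chloropyridinyl group for another. The expected change is small, a 1.5-fold higher number from compound 3 to compound 4 (0.18 log units; within the scatter), leaning toward weaker inhibition in this assay. For compound 4 the estimated value is 60000 nM, with an expected range of 20000 nM to 100000 nM.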

Compound 4, half-maximal inhibitory concentration: 14800 nM
For compound 4 the middle estimate is 4.1-fold (0.61 log units) above the measured one, outside the stated range (below it).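

Exchanging 6-chloropyridin-2-yl for 3-chloropyridin-2-yl on the amide-type nitrogen gives, in this assay, a 2.7-fold lower number from compound 3 to compound 4 (0.42 log units; beyond the scatter), so rearranging the same atoms within this group is enough to shift the result. The group in compound 4 also gives an at least 6.7-fold lower number from compound 2 to compound 4 (0.82 log units; beyond the scatter) and an at least 6.7-fold lower number from compound 1 to compound 4 (0.82 log units; beyond the scatter). These last two steps are only bounds because their starting values are limits and not numbers: the limit of > 100000 nM in this assay, at which 2 of the 4 values shown sit.

Going by these compounds, it remains open whether the chlorine is needed at all, as a plain pyridin-2-yl group on this nitrogen would show. A 3-methylpyridin-2-yl group could test whether another group can take its place.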